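This account rests on a few compounds, and the source may have more. Where it says the series, first, only, none or still open, it means among the compounds named here.

In a physicochemical assay for solubility, at pH 1.1 (on this read-out higher numbers stand for higher solubility and lower numbers for lower solubility), compound 1 `CCN(Cc1ccc(OCCN2C(=O)CCC2=O)c(C)c1)C(CC(=O)O)c1ccc(Cl)cc1` gives 3000000 nM. Compound 2 `CCN(Cc1ccc(OCCn2c(=O)ccn(C)c2=O)c(C)c1)C(CC(=O)O)c1ccc(Cl)cc1` stands level with it at 3000000 nM, and no other measurement is available for comparison. The next compound, compound 3 `Cc1cc(CN(CC2CC2)C(CC(=O)O)c2ccc(Cl)cc2)ccc1OCCn1c(=O)ccn(C)c1=O`, keeps the rest of compound 2 and alters one small group: cyclopropyl in place of methyl on a saturated chain carbon bound to an amine nitrogen. Put simply, this is cyclopropyl in place of methyl on a saturated chain carbon bound to an amine nitrogen. Cut one bond further out, the same difference reads ethyl to cyclopropylmethyl.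

Within the data shown here, only one measured step is available as a guide: no change at the digits printed from compound 1 to compound 2 (within the scatter). That step exchanged a different group at a different place, so it bears on the new change only indirectly. Among the measured compounds shown here, no measured pair tests a change at the amine nitrogen, and the data therefore give no direction for this one. Given that flat step from compound 1, no shift beyond the scatter is expected in this assay. The expected step is no change at the digits printed from compound 2 to compound 3 (within the scatter). For compound 3, the estimated value is 3000000 nM, with an expected range from 1500000 nM to 4000000 nM.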

Compound 3, solubility: 3000000 nM
The estimate for compound 3 equals the measured number at the digits printed; the range from low to high includes it.
By their numbers in this assay, from the lowest: compounds 1, 2 and 3 (each within the scatter of the next).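

In this assay, cyclopropyl in place of methyl on a saturated chain carbon bound to an amine nitrogen gives no change at the digits printed from compound 2 to compound 3 (within the scatter). Among these compounds, this is the first reading at this position, since the earlier pair differed at another place, and it shows that here a three-membered ring of carbon can take the place of methyl with no shift on this read-out, at least in this single pair. No measurement among those shown offers an explanation for this flat step.

Still open, on these data alone, is whether a group of a different kind on this carbon, such as an amine, a hydroxyl or a phenyl ring, or a longer chain such as butyl, would also leave the read-out level in this assay. Also open, as far as these compounds go, is whether ethyl to cyclopropylmethyl would read the same with the other group of compound 1 in place, since a single pair cannot show whether the flat result carries over to a different part of the molecule.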